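The source may report more compounds than this note shows. Statements on the series, on what has been measured and on what is new or still open speak of the compounds shown alone.

Values in an ADME assay on the whole organism (Rattus norvegicus, strain Sprague-Dawley) for pharmacokinetics, using cassette dosing, at a dose of 0.5 mg/kg by the intravenous route; on this read-out lower numbers stand for slow clearance and higher numbers for fast clearance:
- compound 1 `O=C(Nc1ccc2[nH]c(=O)oc2c1)C(=O)N1CCN(c2ccc(Cl)cc2)CC1`: 7.2 mL/min/kg
- compound 2 `O=C(Nc1ccc2[nH]c(=O)oc2c1)C(=O)N1CCN(c2ccc(F)c(Cl)c2)CC1`: 18.3 mL/min/kg
- compound 3 `C[C@@H]1CN(C(=O)C(=O)Nc2ccc3[nH]c(=O)oc3c2)CCN1c1ccc(Cl)cc1`: not yet measured

Of the two measured compounds, compound 1 has the lower number, 7.2 mL/min/kg. Compound 3 keeps the 4-chlorophenyl group of compound 1 and differs from it by methyl in place of hydrogen on a saturated ring carbon. Among the measured compounds shown here, the only measured step, a 2.5-fold higher number from compound 1 to compound 2 (0.41 log units; beyond the scatter), is modest and changes the aryl group, not the ring carbon. It therefore bears on the new change only indirectly, as a guide to how far one small edit can move this assay here. For the measured compounds named here, no measured compound carries a substituent on this ring carbon, so the direction is poorly supported. The expected move is a 1.4-fold higher number from compound 1 to compound 3 (0.14 log units; within the scatter), a small rise that may stay within the scatter. For compound 3 the estimated clearance is 10 mL/min/kg, with an expected range of 4.5 mL/min/kg to 22 mL/min/kg.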

Compound 3, clearance: 15.6 mL/min/kg
Compound 3: middle estimate off by 1.6-fold (0.19 log units), on the low side; the range from low to high includes it.
By their numbers in this assay, from the lowest: compound 1; then compounds 3 and 2 (each within the scatter of the next).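

In this assay the step of a 2.2-fold higher number from compound 1 to compound 3 (0.34 log units; beyond the scatter) marks the saturated ring carbon next to the ring atom that bears a 4-chlorophenyl group as a place where one added methyl raises the number beyond the scatter, with the aryl group unchanged. The earlier step of a 2.5-fold higher number from compound 1 to compound 2 (0.41 log units; beyond the scatter) had shown such a rise only for a change of the aryl group, so the series now has two separate places where a small edit leaves compound 1 with the lower number. Nothing measured here explains the rise at the ring carbon.

Open, as far as these compounds go, is whether the mirror-image placement of the methyl, or an ethyl or hydroxymethyl group on the same carbon, would move the number the same way. Also open, from the compounds shown here alone, is whether the methyl has a similar effect alongside the 3-chloro-4-fluorophenyl group.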